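The compounds below may be only part of what the source reports. "The series", "measured", "known", "first", "only" and "open" are said of these compounds alone.

Compound 1 `Cc1nc(S(C)(=O)=O)ccc1Oc1ncnc(OC2CCN(C(=O)OC(C)(C)CF)CC2)c1F` has the lower of the two numbers recorded in a functional assay on isolated protein for inhibition of Glucose-dependent insulinotropic receptor (Rattus norvegicus), read by HTRF and cAMP accumulation (a higher number here means that more compound is needed for the effect, a lower number that less compound is needed), where compound 1 gives 138 nM, while compound 2 `Cc1nc(S(C)(=O)=O)ccc1Oc1ncnc(OC2CCN(C(=O)O[C@@H](C)CF)CC2)c1F` gives 1680 nM. Going by the values given here, the one step recorded between them, a 12-fold higher number from compound 1 to compound 2 (1.09 log units; beyond the scatter), is the only guide for compound 3 `Cc1nc(S(C)(=O)=O)ccc1Oc1ncnc(OC2CCN(C(=O)SC(C)C)CC2)c1F`, which differs from compound 1 by a group of 4 heavy atoms (3 carbon, 1 sulfur; no ring) in place of a group of 6 heavy atoms (4 carbon, 1 oxygen, 1 fluorine; no ring), on a carbonyl carbon. That earlier step bears on this change only loosely, since the carbonyl carbon now carries a sulfur-linked group rather than an oxygen-linked one, but it shows that trimming the group on that carbon costs potency. A loss of similar size, a 5.8-fold higher number from compound 1 to compound 3 (0.76 log units; beyond the scatter), is therefore expected. Compound 3 is estimated at 800 nM in this assay, with a range from 250 nM to 2500 nM.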

Compound 3, half-maximal effective concentration: 41.3 nM
Compound 3: middle estimate off by 19-fold (1.29 log units), on the high side, outside the stated range (below it).
By their numbers in this assay, from the lowest: compound 3; then compound 1; then compound 2.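

In this assay, the carbonyl carbon accepts isopropylsulfanyl with a gain, a 3.3-fold lower number from compound 1 to compound 3 (0.52 log units; beyond the scatter), so a smaller group there need not cost potency. The same group gives a 41-fold lower number from compound 2 to compound 3 (1.61 log units; beyond the scatter), and the order of the three compounds does not follow group size: compound 2, whose group is larger than that of compound 3 and smaller than that of compound 1, has the highest number. Nothing available explains this gain.

Going by these compounds, it remains open whether the sulfur link or the isopropyl part drives the result. An isopropoxy group on the same carbon would separate the two, and a tert-butylsulfanyl group would test a larger group on sulfur.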